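Cyclopropyl in place of methylcarbamoyl: working notes

The source may hold more compounds than are shown below. What is called first, only, known or untested is meant among the compounds shown, and "the series" means these compounds.

Of the compounds shown here, two have been measured so far in a physicochemical assay for lipophilicity, at pH 7.4; a lower number here means a more polar compound, a higher number a more lipophilic compound. Compound 1 (`Cc1cc([C@](C)(O)C#Cc2cc3c(cc2F)C2CC(C2)n2cc(C(N)=O)nc2-3)no1`) gives 3.3, and compound 2 (`CNC(=O)c1c(C(N)=O)nc2n1C1CC(C1)c1ccc(C#CC(C)(C)c3ncc(C)o3)cc1-2`) gives 3.7. Compound 2 therefore holds the higher of the two numbers, and the gap between them lies beyond the usual scatter. Two values cannot establish a trend, and they do not isolate the contribution of any single group.

The next compound to be measured is compound 3 (`Cc1cnc(C(C)(C)C#Cc2ccc3c(c2)-c2nc(C(N)=O)c(C4CC4)n2C2CC3C2)o1`). It carries cyclopropyl in place of methylcarbamoyl on an aromatic carbon of the five-membered aromatic ring, and otherwise matches compound 2: cyclopropyl in place of methylcarbamoyl on an aromatic carbon. Among the measured compounds shown here, no measured pair covers this exchange, so the expectation rests on the counts in the structural change alone, which leaves it uncertain. The expected change in this assay is upward and beyond the scatter, with an estimated a number 0.60 log units higher from compound 2 to compound 3 (beyond the scatter). For compound 3 the estimated value is 4.3, with an expected range of 3.8 to 4.8.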

Compound 3, distribution coefficient: 4.4
The estimate for compound 3 lay 0.10 log units below the measured number; the range from low to high includes it.
By their numbers in this assay, from the lowest: compound 1; then compound 2; then compound 3.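

Among the compounds shown here, at this position, the aromatic carbon of the five-membered aromatic ring, next to the ring nitrogen, the exchange of methylcarbamoyl for cyclopropyl gives the first step that can be tied to one place: in this assay the number is a number 0.70 log units higher from compound 2 to compound 3 (beyond the scatter). The earlier pair could not show this, since compound 1 and compound 2 differ in more than one place, whereas here the position is shown to be one at which a single exchange moves the read-out beyond the scatter, with methylcarbamoyl and its hydrogen-bond donor and acceptor giving way to a carbon-only three-membered ring. Nothing available assigns this step to any feature of either group, so it stands as an observation on this one pair.

Still open, as far as these compounds go, is how an amine, a carboxylic acid or a longer chain on this same carbon would place in this assay relative to compound 2 and compound 3, which would show whether the step follows the loss of the amide or the arrival of the ring. Also open, from the compounds shown here alone, is whether cyclopropyl at this position would give a step of similar size on the core of compound 1.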